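Carbamate to amide on the indole nitrogen carboxamide

The source may hold more compounds than are shown below. What is called first, only, known or untested is meant among the compounds shown, and "the series" means these compounds.

The compounds measured in a functional assay on trachea for agonist activity at cysteinyl leukotriene receptor (Homo sapiens) (a higher number here means a weaker inhibitor, a lower number a stronger inhibitor), are:
compound 1 `COc1cc(C(=O)O)ccc1Cn1ccc2ccc(NC(=O)OC3CCCC3)cc21`, which gives 15.7 nM;
compound 2 `COc1cc(C(=O)NS(=O)(=O)c2ccccc2C)ccc1Cc1cn(C)c2ccc(NC(=O)CC3CCCC3)cc12`, which gives 24.5 nM;
compound 3 `CNC(=O)CCc1cn(Cc2ccc(C(=O)NS(=O)(=O)c3ccccc3C)cc2OC)c2cc(C(=O)NCC3CCCC3)ccc12`, which gives 0.399 nM.

Compound 1 stands second highest of the three numbers. Its nearest neighbour is compound 2, whose number is slightly higher, a gap that lies within the scatter of this assay, so no order between the two can be claimed. Compound 3 stands furthest away, with a number well below that of compound 1, a gap that lies beyond the scatter.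

The unmeasured compound 4 `COc1cc(C(=O)O)ccc1Cn1ccc2ccc(NC(=O)CC3CCCC3)cc21` differs from compound 1 in a single place: cyclopentylmethyl in place of cyclopentyloxy on a carbonyl carbon. The carbamate oxygen of compound 1 thus gives way to a methylene, the ring and the carbonyl being kept. Among the compounds with values here, no pair of measured compounds shows this exact change, so the step has to be judged from the structures alone. Compound 2 carries the same (cyclopentylmethyl)carbonyl amino group on a differently built core and gives a number close to that of compound 1, which argues for a modest effect.

The step from compound 1 to compound 4 is expected to be a 1.4-fold higher number from compound 1 to compound 4 (0.15 log units; within the scatter), within or close to the scatter, with a slight lean towards a higher number. Compound 4 is therefore estimated at 22 nM, with a range from 7 nM to 70 nM.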

Compound 4, antagonist equilibrium constant: 20.7 nM
Beside the measured number, compound 4's estimate is 1.1-fold (0.03 log units) above it, within the range that was stated.
By their numbers in this assay, from the lowest: compound 3; then compounds 1, 4 and 2 (each within the scatter of the next).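

In this assay, cyclopentylmethyl in place of cyclopentyloxy on a carbonyl carbon gives a small step (a 1.3-fold higher number from compound 1 to compound 4 (0.12 log units; within the scatter)), so compound 1 and compound 4 cannot be told apart. This is the only pair shown that differs in one place, and it indicates that, on the core of compound 1, the oxygen of the carbamate can give way to a methylene without a difference this assay can resolve, even though the hydrogen-bond acceptor counted in cyclopentyloxy is absent from cyclopentylmethyl. No supporting data bear on why the two groups read alike.

The compounds shown leave open whether other groups on this carbonyl carbon, such as a cyclohexyl ring, a longer chain or an amine, would read differently from cyclopentylmethyl and cyclopentyloxy. They also leave open whether the same exchange would read alike on the core of compound 2, which carries the ((cyclopentylmethyl)carbonyl)amino group but has no cyclopentyloxy partner among the compounds shown.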